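This account rests on a few compounds, and the source may have more. Where it says the series, first, only, none or still open, it means among the compounds named here.

Measured in an ADME assay on Vero cells (Chlorocebus sabaeus) for cytotoxicity, read by MTT assay, with a stated time of 72 h; on this read-out lower numbers stand for stronger inhibition and higher numbers for weaker inhibition:

Compound 1 `COc1ccc(CNc2cc(-c3ccco3)ncn2)cc1`: "not determined" (no result reported)
Compound 2 `CCNc1c(NCc2ccc(OC)cc2)ncnc1-c1ccco1`: "not determined" (no result reported)
Compound 3 `COc1ccc(CNc2ncnc(-c3ccco3)c2NC=O)cc1`: > 40 ug/mL

Within the data shown here, compound 1 and compound 2 have no reported result, so compound 3 is the only compound with any reading to work from. Compound 3 gives > 40 ug/mL, which is a limit of the assay and not a number. Among the measured compounds shown here, this is the only reading of its kind so far: the limit of > 40 ug/mL in this assay, at which 1 of the 3 values shown sits. On these data alone, its exact position therefore remains unknown.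

Compound 4 `COc1ccc(CNc2nc(Cl)nc(-c3ccco3)c2NC=O)cc1` has chloro in place of hydrogen on an aromatic carbon, between two ring nitrogen atoms and para to a formylamino group: chloro in place of hydrogen on an aromatic carbon. For the measured compounds named here, no measured pair shows what this change does in this assay, so the expectation rests on a single limit and stays wide. No step beyond the usual scatter is expected, in either direction. The expected step of a number no higher from compound 3 to compound 4 (the limit leaves the size open) is only an estimate. For compound 4 the estimated value is 40 ug/mL, with an expected range from 15 ug/mL to 100 ug/mL.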

Compound 4, half-maximal inhibitory concentration: > 40 ug/mL
Compound 4: only a limit was reported (the forecaster's own chance of this, stated with the estimate: 60%); the middle value lies on the limit itself.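

Compound 3 and compound 4 each give only a limit of the assay and not a number, so no step can be read for chloro in place of hydrogen: the limit of > 40 ug/mL in this assay, at which 2 of the 4 values shown sit. The compounds shown leave open where either compound truly lies and whether chloro shifts the reading at all.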